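Removing One Chloro From a Trichlorophenyl Ether

This account rests on a few compounds, and the source may have more. Where it says the series, first, only, none or still open, it means among the compounds named here.

Compound 2 (`NC1=NC2(CCOCC2)N(OCCCOc2cc(Cl)c(Cl)cc2Cl)C(N)=N1`) sits at a limit in an assay on isolated protein for inhibition of Dihydrofolate reductase (Homo sapiens), read by spectrophotometry, using NADPH, with stated times of 5 s and 6 min, tested at 5 uM; a higher number here means a stronger effect of the compound at the concentration tested, a lower number a weaker effect: it gives > 90%, a limit of the assay rather than a number. Compound 1 (`NC1=NC2(CCOCC2)N(OCCCOc2ccc(Cl)c(Cl)c2)C(N)=N1`) also stands at a limit. In this assay compound 1 gives > 90%, again a limit. The step that the two limits leave unreadable from compound 1 to compound 2 is therefore unreadable, since both values rest on (the limit of > 90% in this assay, at which 2 of the 2 values shown sit). Compound 3 (`NC1=NC2(CCOCC2)N(OCCCOc2ccc(Cl)cc2Cl)C(N)=N1`) is not yet measured. It differs from compound 2 as follows: hydrogen in place of chloro on an aromatic carbon. Within the data shown here, the only measured step, that from compound 1 to compound 2, concerns a chloro entering rather than leaving and shows no readable size, so it gives no direction for the present change. Since both measured compounds rest at the same limit, compound 3 is expected to remain there as well, with a step that the limit leaves unreadable from compound 2 to compound 3 meaning no step beyond the scatter. The estimate for compound 3 in this assay is 92%, ranging from 78% to 100%.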

Compound 3, a percentage reported as inhibition, at one concentration (the size of the read-out at that concentration, not a potency): > 90%
Compound 3: a limit, no number; the forecaster's own chance of this, stated with the estimate: 70%; the middle value is on the limit's open side.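

Among these compounds, no step among compound 1, compound 2 and compound 3 can be read in this assay, because each value is a limit and not a number: the limit of > 90% in this assay, at which 3 of the 3 values shown sit.

The compounds shown leave open whether the 3,4-dichlorophenyl, 2,4,5-trichlorophenyl and 2,4-dichlorophenyl compounds differ at all in inhibition, and by how much.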